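The source may hold more compounds than are shown below. What is called first, only, known or untested is meant among the compounds shown, and "the series" means these compounds.

Measured so far in a functional assay on MKN-74 cells (Homo sapiens) for antiproliferative activity, with a stated time of 24 h; on this read-out lower numbers stand for stronger inhibition and higher numbers for weaker inhibition:
compound 1 `NC(=O)c1c(NC(=O)c2ccccc2)sc2c1CCN(C(=S)Nc1ccccc1Cl)C2`: 11800 nM
compound 2 `COc1ccccc1C(=O)Nc1sc2c(c1C(N)=O)CCN(C(=S)Nc1ccccc1Cl)C2`: 20500 nM

Within the data shown here, on these numbers compound 2 and compound 1 are not separated: the only measured step, a 1.7-fold higher number from compound 1 to compound 2 (0.24 log units; within the scatter), lies within the scatter, so compound 2 stands level with compound 1 rather than apart from it.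

Compound 3 `NC(=O)c1c(NC(=O)c2cccc([N+](=O)[O-])c2)sc2c1CCN(C(=S)Nc1ccccc1Cl)C2` differs from compound 2 by 3-nitrophenyl in place of 2-methoxyphenyl on a carbonyl carbon. Among the measured compounds shown here, the one measured step that bears on this, a 1.7-fold higher number from compound 1 to compound 2 (0.24 log units; within the scatter), also exchanged the group on that same carbonyl carbon and produced no change beyond the scatter. For the measured compounds named here, no measured step involves a 3-nitrophenyl group, so nothing in the data points to a larger effect in either direction. The expected step is therefore none beyond the scatter, a 1.4-fold lower number from compound 2 to compound 3 (0.14 log units; within the scatter). Compound 3 is estimated at 15000 nM in this assay, with a range from 5000 nM to 45000 nM.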

Compound 3, half-maximal inhibitory concentration: 8850 nM
Compound 3: the middle estimate sits 1.7-fold (0.23 log units) above what was measured; measured number inside the range.
By their numbers in this assay, from the lowest: compounds 3, 1 and 2 (each within the scatter of the next, the first and the last beyond it).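

In this assay, among these compounds, the group on this carbonyl carbon can move the number beyond the scatter: 3-nitrophenyl in place of 2-methoxyphenyl gives a 2.3-fold lower number from compound 2 to compound 3 (0.36 log units; beyond the scatter) and is the first separation, though a modest one. Nitro in place of hydrogen gives only a 1.3-fold lower number from compound 1 to compound 3 (0.12 log units; within the scatter) and so stays within the scatter, which leaves compound 1 level with both compound 2 and compound 3, and only those two apart. No measurement available here explains the difference.

The step from compound 2 to compound 3 changes both the group and its place on the ring, so a 3-methoxyphenyl or 2-nitrophenyl group would be needed to separate those two changes. On these data alone, it also remains open how an amine or a carboxylic acid on that ring would read in this assay on this scale.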